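The source may hold more compounds than are shown below. What is called first, only, known or untested is meant among the compounds shown, and "the series" means these compounds.

Compound 1, `COc1cc(C(=O)NS(=O)(=O)c2ccccc2)ccc1Cc1c[nH]c2ccc(NC(=O)OC3CCCC3)cc12`, gives 9.8 in an assay on isolated protein (Cavia porcellus) with cysteinyl leukotriene receptor (Homo sapiens) as the target; a higher number here means a more potent compound, by a factor of ten per unit of this negative logarithm, a lower number a less potent compound.
Compound 2, `COc1cc(C(=O)NS(=O)(=O)c2ccccc2)ccc1Cc1cn(C2CCCC2)c2ccc(NC(=O)OC3CCCC3)cc12`, gives 7.84 in this assay.

Compound 1 stands highest of the two measured compounds. Within the data shown here, the single measured step is a number 1.96 log units lower from compound 1 to compound 2 (beyond the scatter); it puts cyclopentyl in place of hydrogen on an aromatic nitrogen and leaves the rest of the shared core untouched.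

Compound 3, `COc1cc(C(=O)O)ccc1Cc1c[nH]c2ccc(NC(=O)OC3CCCC3)cc12`, has not yet been measured in this assay. It differs from compound 1 at another place: hydroxy in place of (phenylsulfonyl)amino on a carbonyl carbon. Among the measured compounds shown here, no measured step touches this carbonyl carbon, so the one known step, from a hydrogen to cyclopentyl on the aromatic nitrogen, does not bear on it directly; it shows only that the shared core tolerates a change at the nitrogen poorly. The part that leaves is large and the part that enters small, so some loss of potency is expected rather than none, though smaller than the known step. The expected step is a number 0.80 log units lower from compound 1 to compound 3 (beyond the scatter). Compound 3 is therefore expected to give about 9, within a range from 8.2 to 9.8.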

Compound 3, negative logarithm of the antagonist equilibrium constant: 7.32
For compound 3 the middle estimate is 1.68 log units above the measured one; measured number below the stated range.
By their numbers in this assay, from the lowest: compound 3; then compound 2; then compound 1.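

Among these compounds, this step shows that the carbonyl carbon, which no earlier compound changed, also matters for potency in this assay: hydroxy in place of (phenylsulfonyl)amino gives a number 2.48 log units lower from compound 1 to compound 3 (beyond the scatter). The (phenylsulfonyl)carbamoyl group of compound 1 therefore cannot be cut back to the carboxy group of compound 3 without a large loss, even though the rest of the molecule stays the same. Compound 1 now has a large measured step down at two separate places, this carbonyl carbon and the aromatic nitrogen, and nothing available here explains the loss at either one.

The compounds shown leave open which part of the (phenylsulfonyl)amino group matters, since the phenyl ring, the sulfonyl and the nitrogen all leave together in this one change. A methylsulfonylamino group on the same carbonyl carbon would test the phenyl ring alone, while a plain amino group there would remove the whole sulfonyl part but keep the nitrogen, so that the contribution of each part could be read separately.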